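The source may report more compounds than this note shows. Statements on the series, on what has been measured and on what is new or still open speak of the compounds shown alone.

Compound 1 `CC(C)NC(=O)N(CCCCCSc1nc(-c2ccccc2)c(-c2ccccc2)[nH]1)CCOCCO` was tested in an assay on microsomes from liver with sterol O-acyltransferase 1 (Rattus norvegicus) as the target (a lower number here means a stronger inhibitor, a higher number a weaker inhibitor), where compound 1 gives 90 nM. Among the three measured compounds it stands second highest. Compound 2 `CCCCCCCN(CCCCCSc1nc(CCC)c(CCC)[nH]1)C(=O)Nc1ccc(F)cc1F` gives 60 nM in this assay, a value within the scatter of that of compound 1, so the two cannot be told apart. Compound 3 `CCCCCCCN(CCOCCSc1nc(-c2ccc(OC)cc2)c(-c2ccc(OC)cc2)[nH]1)C(=O)NC(C)C` gives 850 nM, and the gap between compound 1 and compound 3 lies beyond the scatter, with compound 3 the weaker of the two.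

Compound 4 `CCCCOCCN(CCCCCSc1nc(-c2ccccc2)c(-c2ccccc2)[nH]1)C(=O)NC(C)C` has not yet been measured. Going by the values given here, it differs from compound 1 in one place: ethyl in place of hydroxy on a saturated chain carbon, two bonds along the chain from an oxygen on a saturated carbon No pair of measured compounds isolates this change, so nothing can be read across from a known step. The change is expected to move the number in this assay only a little, toward a lower value, and perhaps no further than the scatter. The estimated step is a 1.5-fold lower number from compound 1 to compound 4 (0.18 log units; within the scatter). For compound 4 the expected value in this assay is 60 nM, with a range from 20 nM to 180 nM.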

Compound 4, half-maximal inhibitory concentration: 190 nM
Beside the measured number, compound 4's estimate is 3.2-fold (0.50 log units) below it; measured number outside the range, above it.
By their numbers in this assay, from the lowest: compounds 2 and 1 (each within the scatter of the next); then compound 4; then compound 3.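

In this assay, ethyl in place of hydroxy on a saturated chain carbon, two bonds along the chain from an oxygen on a saturated carbon, gives a 2.1-fold higher number from compound 1 to compound 4 (0.32 log units; beyond the scatter) and so makes compound 4 the weaker inhibitor of the pair. Going by these compounds alone, the step is modest, but it shows that this position is not indifferent to the change, which the earlier compounds, differing from one another in several places, could not show. Nothing available here accounts for the direction of this step.

The pair leaves open whether the step follows from losing the hydroxy or from gaining chain length, since the two change together, and a methoxy group or an amine at the same place would help separate them. It also leaves open whether the same step would hold with the other cores and urea substituents seen in compound 2 and compound 3.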